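Swapping 4-methylphenyl for benzyl on the amide nitrogen

The source may hold more compounds than are shown below. What is called first, only, known or untested is meant among the compounds shown, and "the series" means these compounds.

In a functional assay on the whole organism with Mus musculus as the target, in the maximal electroshock model, with a stated time of 3 h (a higher number here means that more compound is needed for the effect, a lower number that less compound is needed), compound 1 `Cc1ccccc1NC(=O)CNC(=O)OCc1ccccc1` gives 74.3 mg/kg and compound 2 `Cc1ccc(NC(=O)CNC(=O)OCc2ccccc2)cc1` gives 27.4 mg/kg. Compound 2 therefore holds the lower of the two numbers, meaning that less of it is needed for the effect.

The next compound to be measured is compound 3 `O=C(CNC(=O)OCc1ccccc1)NCc1ccccc1`. It carries benzyl in place of 4-methylphenyl on an amide-type nitrogen. Compound 2 and compound 3 have the same atoms, joined differently.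

Going by the values given here, only one measured step bears on this change. Moving the methyl group, with 4-methylphenyl in place of 2-methylphenyl on the same nitrogen, gave a 2.7-fold lower number from compound 1 to compound 2 (0.43 log units; beyond the scatter), a modest step. Among the compounds with values here, it shows that a rearrangement at this nitrogen can shift the number, but it does not show what benzyl will do, since no measured compound carries that group there. No direction can be read from the data, so no step beyond the scatter is expected. The expected change is a 1.1-fold lower number from compound 2 to compound 3 (0.06 log units; within the scatter). For compound 3 the estimated value is 24 mg/kg, with an expected range from 7 mg/kg to 80 mg/kg.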

Compound 3, dose for half-maximal effect: 11.6 mg/kg
Beside the measured number, compound 3's estimate is 2.1-fold (0.32 log units) above it, and the stated range covers the measured number.
By their numbers in this assay, from the lowest: compound 3; then compound 2; then compound 1.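

The three compounds show that this nitrogen is sensitive to more than where a methyl group sits on the ring. Benzyl and 4-methylphenyl share the same atoms and the same counts of rings, hydrogen-bond donors and acceptors, yet this assay gives a 2.4-fold lower number from compound 2 to compound 3 (0.37 log units; beyond the scatter), so rearranging those atoms within the group is enough to move the number beyond the scatter. Compared with the 2-methylphenyl group, the benzyl group gives a 6.4-fold lower number from compound 1 to compound 3 (0.81 log units; beyond the scatter), which makes compound 3 the compound needing the least for the effect among these three, though nothing available explains why benzyl gives this result.

On these data alone, it remains open whether a longer chain, such as 2-phenylethyl, on the same nitrogen would lower the number further or raise it again, and three compounds cannot define a trend. As far as these compounds go, it is equally open how a fluorine or a methoxy group on the benzyl ring would change the number, or whether the result for benzyl would carry over to a core with another group in place of the benzyl carbamate.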